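A few compounds are considered here, and "the series" means these few. Any claim that something is new, unique, unknown or untested is made for them only; others in the source may bear on it.

Measured so far in a functional assay on EOL1 cells (Homo sapiens) for inhibition, read by fluorescence, with a stated time of 72 h; on this read-out higher numbers stand for weaker inhibition of growth and lower numbers for stronger inhibition of growth:
- compound 1 `COc1ccc(Nc2nc(N[C@H]3CC[C@H](N)CC3)nc3c2ncn3CCC(C)C)c(OC)c1`: 630 nM
- compound 2 `CC(C)CCn1cnc2c(Nc3ccc(Cl)cc3)nc(N[C@H]3CC[C@H](N)CC3)nc21`: 90 nM
- compound 3 `CCCCCCn1cnc2c(Nc3cccc(Cl)c3)nc(N[C@H]3CC[C@H](N)CC3)nc21`: 310 nM

Among these three, compound 3, at 310 nM, lies below compound 1 and above compound 2. The next compound, compound 4 `CC(C)CCn1cnc2c(Nc3cccc(Cl)c3)nc(N[C@H]3CC[C@H](N)CC3)nc21`, is not yet measured. It differs from compound 3 by isopropyl in place of butyl on a saturated chain carbon, two bonds along the chain from an aromatic nitrogen. Cut one bond further out, this reads hexyl to isopentyl.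

Among the measured compounds shown here, no measured step changes this chain. For the measured compounds named here, the only measured step, a 7.0-fold lower number from compound 1 to compound 2 (0.85 log units; beyond the scatter), is 4-chlorophenyl in place of 2,4-dimethoxyphenyl, so it bears only indirectly. Compound 2 gives 90 nM and carries the isopentyl chain of compound 4, but its chlorophenyl group differs from that of compound 4. A small move towards a lower number is therefore expected in this assay. The expected change is a 1.9-fold lower number from compound 3 to compound 4 (0.29 log units; within the scatter). Compound 4 is estimated at 160 nM, with an expected range of 60 nM to 380 nM.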

Compound 4, concentration for 50% growth inhibition: 60 nM
Compound 4: the middle estimate sits 2.7-fold (0.43 log units) above what was measured; the measured number falls inside the stated range.
By their numbers in this assay, from the lowest: compounds 4 and 2 (each within the scatter of the next); then compound 3; then compound 1.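

In this assay, among the compounds shown here, the chain position proves sensitive: with 3-chlorophenyl held constant, hexyl to isopentyl gives a 5.2-fold lower number from compound 3 to compound 4 (0.71 log units; beyond the scatter) and is the first measured change at this chain. With isopentyl held constant, the exchange of 4-chlorophenyl for 3-chlorophenyl gives a 1.5-fold lower number from compound 2 to compound 4 (0.18 log units; within the scatter) and does not separate the two chlorophenyl groups, whereas 3-chlorophenyl in place of 2,4-dimethoxyphenyl gives an 11-fold lower number from compound 1 to compound 4 (1.02 log units; beyond the scatter) and is the largest step shown. No available evidence bears on the reason for these steps.

The compounds shown leave open how a shorter chain such as propyl or a ring-bearing group such as cyclopentylmethyl would read at this position. On these data alone, it also remains open whether the step from hexyl to isopentyl holds with 4-chlorophenyl or with 2,4-dimethoxyphenyl on the shared core.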